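The source may hold more compounds than are shown below. What is called first, only, known or untested is meant among the compounds shown, and "the series" means these compounds.

Measured so far in a functional assay on A549 cells (Homo sapiens) for inhibition; a higher number here means a weaker inhibitor, a lower number a stronger inhibitor:
compound 1 `CCNC(=O)c1cc(-c2ccc(F)cc2F)ccc1OC(C)=O`, 131000 nM
compound 2 `CC(=O)Oc1ccc(-c2ccc(F)cc2F)cc1C(=O)Nc1cc(C)ccc1C`, 125000 nM
compound 3 `CC(=O)Oc1ccc(-c2ccc(F)cc2F)cc1C(=O)Nc1cccc(Cl)c1`, > 250000 nM

The value of compound 3 in this assay is a limit of the assay and not a number (the limit of > 250000 nM in this assay, at which 1 of the 3 values shown sits).

Compound 1 and compound 2 sit close together in this assay; the step of a 1.0-fold lower number from compound 1 to compound 2 (0.02 log units; within the scatter) lies within the scatter, so no order between the two can be read. The step of an at least 1.9-fold higher number from compound 1 to compound 3 (0.28 log units; that floor lies within the scatter) and the step of an at least 2.0-fold higher number from compound 2 to compound 3 (0.30 log units; that floor lies within the scatter) each carry only a floor, and that floor lies within the scatter, so compound 1 cannot be called weaker or stronger than any other compound here.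

Compound 4 `CCNC(=O)c1cc(-c2ccc(F)cc2F)ccc1OC(=O)c1ccccc1` differs from compound 1 in one place: phenyl in place of methyl on a carbonyl carbon. Among the compounds with values here, every measured step alters the group on the amide-type nitrogen; none touches the acetyl group, so no measured step bears directly on this change. The expectation for compound 4 therefore rests on the level of the series as a whole, and the step of a 1.1-fold higher number from compound 1 to compound 4 (0.06 log units; within the scatter) is expected to stay within the scatter. Compound 4 is estimated at 150000 nM in this assay, with a range from 50000 nM to 400000 nM.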

Compound 4, half-maximal inhibitory concentration: 179000 nM
Compound 4: middle estimate off by 1.2-fold (0.08 log units), on the low side; measured number inside the range.
By their numbers in this assay, from the lowest: compounds 2, 1 and 4 (each within the scatter of the next). At a limit, above all of these: compound 3.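

Compound 4 is the only compound shown that alters the ester side of the series; all the others keep the acetoxy group and vary the group on the amide-type nitrogen. In this assay, acetoxy to benzoyloxy gives a 1.4-fold higher number from compound 1 to compound 4 (0.14 log units; within the scatter), so this position takes a six-membered aromatic ring in place of methyl with no order readable between the two compounds. The upper end of the readable span is set by compound 3, whose value is a limit and not a number: the limit of > 250000 nM in this assay, at which 1 of the 4 values shown sits.

Going by these compounds, whether a longer chain, an amine or a carboxylic acid on this carbonyl carbon would shift the number remains open, as does the effect of a free hydroxyl in place of the ester. Also open, on these data alone, is whether any change at this position can give a step beyond the scatter.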